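This account rests on a few compounds, and the source may have more. Where it says the series, first, only, none or still open, it means among the compounds named here.

Measured so far in an ADME assay on NIH3T3 cells (Mus musculus) for inhibition, read by MTT assay, with a stated time of 48 h; a higher number here means a weaker inhibitor, a lower number a stronger inhibitor:
Compound 1 `C(=C/c1nc2ccccn2c1Sc1ccccc1)\c1ccccc1`: > 100000 nM, a limit.
Compound 2 `Cc1ccc(-c2nc3ccc(C)cn3c2Sc2ccccc2)cc1`: > 100000 nM, a limit.
Compound 3 `Clc1ccc2nc(-c3ccccc3)c(Sc3ccccc3)n2c1`: > 100000 nM, a limit.

Compound 1 has no number to its name and stands at the limit of the assay. The same is true of the whole set, which shows only (the limit of > 100000 nM in this assay, at which 3 of the 3 values shown sit). For the measured compounds named here, no step between two measured compounds is available, so nothing yet shows how far a structural change can move the read-out.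

Compound 4 `Clc1ccc(-c2nc3ccccn3c2Sc2ccccc2)cc1` has not yet been measured. It keeps the shared core and the phenylsulfanyl group of compound 1, but carries 4-chlorophenyl in place of 2-phenylethenyl on an aromatic carbon.

Compound 1 gives > 100000 nM, again a limit, and this is the ground for expecting no step beyond the scatter in this assay, in either direction. The expected change is a number no higher from compound 1 to compound 4 (the limit leaves the size open). For compound 4 the estimated value is 100000 nM, with an expected range from 50000 nM to 200000 nM.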

Compound 4, half-maximal inhibitory concentration: > 100000 nM
Compound 4: no number, only a limit; the forecaster's own chance of this, stated with the estimate: 85%; the middle value sits exactly at the limit.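

Compound 4 gives > 100000 nM, a limit, and compound 1 also stands at a limit, so no step from compound 1 to compound 4 can be read: the limit of > 100000 nM in this assay, at which 4 of the 4 values shown sit.

The compounds shown leave open which structural change, if any, would bring a measurable value in this assay.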